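Second chloro on the aromatic ring of compound 1

The source may hold more compounds than are shown below. What is called first, only, known or untested is meant among the compounds shown, and "the series" means these compounds.

For the measured compounds named here, compound 1 `O=C1/C(=C/c2ccccc2Cl)CCCc2ccccc21` gives 42300 nM in a functional assay on L1210 cells (Mus musculus) for inhibition (on this read-out higher numbers stand for weaker inhibition and lower numbers for stronger inhibition), the second highest of the three numbers so far. Its nearest neighbour is compound 2 `COc1ccccc1/C=C1\CCCc2ccccc2C1=O`, which gives 46100 nM; the step of a 1.1-fold higher number from compound 1 to compound 2 (0.04 log units; within the scatter) lies within the scatter. Furthest away is compound 3 `O=C1/C(=C/c2ccccc2[N+](=O)[O-])Cc2ccccc21`, built on a different core and carrying a nitro group, which gives 7610 nM; no single-point step joins it to compound 1, so the two values show only that the lower number goes together with both a changed core and a changed substituent.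

Compound 4 `O=C1/C(=C/c2ccc(Cl)cc2Cl)CCCc2ccccc21` is compound 1 with chloro in place of hydrogen on an aromatic carbon, the entering chloro standing meta to the chloro group already present and para to a large group. Going by the values given here, no measured step adds or removes a chloro. Among the compounds with values here, the only step on this ring, a 1.1-fold higher number from compound 1 to compound 2 (0.04 log units; within the scatter), swapped one group for another and stayed within the scatter, which gives no ground to expect a shift beyond the scatter here either. The step from compound 1 to compound 4 is therefore expected to be small, a 1.3-fold lower number from compound 1 to compound 4 (0.12 log units; within the scatter). For compound 4 in this assay the estimate is 32000 nM, with a range from 12000 nM to 85000 nM.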

Compound 4, half-maximal inhibitory concentration: > 500000 nM
Compound 4 gave a limit, no number (the forecaster's own chance of this, stated with the estimate: 5%); middle value at least 15-fold (1.19 log units) away from the limit.
By their numbers in this assay, from the lowest: compound 3; then compounds 1 and 2 (each within the scatter of the next). At a limit, above all of these: compound 4.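

In this assay, the aromatic carbon para to a large group and meta to the chloro group proves far from neutral: chloro in place of hydrogen there gives an at least 11-fold higher number from compound 1 to compound 4 (1.07 log units; beyond the scatter), so adding a single chlorine atom takes the series to much weaker inhibition. For the compounds shown here, the value of compound 4 is a limit of the assay and not a number, so this step marks only the smallest shift that the data allow: the limit of > 500000 nM in this assay, at which 1 of the 4 values shown sits. The one earlier step on this ring, a 1.1-fold higher number from compound 1 to compound 2 (0.04 log units; within the scatter), exchanged one group for another at an already substituted carbon and said nothing about this unsubstituted carbon.

Still open is whether the shift belongs to chloro itself or would follow any group at this carbon, such as fluoro, methyl, an amine or a carboxylic acid, and whether it needs the chloro group already present, given that compound 4 alone among the compounds shown carries two chloro groups. Also open, from the compounds shown here alone, is whether the same addition would act alike on the core of compound 3, which carries a nitro group instead of chloro.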